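Heteroaryl exchange on the chain carbon, compound 1 to 3

A few compounds are considered here, and "the series" means these few. Any claim that something is new, unique, unknown or untested is made for them only; others in the source may bear on it.

Measured:
compound 1 `Cc1cc(Nc2ccn(Cc3nc(C)c4ccccc4n3)n2)n2nc(SCc3ccc(Br)cc3)nc2n1` — 5450 nM
compound 2 `Cc1cc(Nc2cc(-c3ccccc3)[nH]n2)n2nc(SCC3CCCCC3)nc2n1` — > 50000 nM

In a functional assay on PC-9 cells (Homo sapiens) for inhibition, read by MTT assay, with a stated time of 72 h (on this read-out lower numbers stand for stronger inhibition and higher numbers for weaker inhibition), compound 1 gives 5450 nM, the only number shown in the series. Compound 2 gives > 50000 nM, which is a limit of the assay and not a number (the limit of > 50000 nM in this assay, at which 1 of the 2 values shown sits). Compound 3 `Cc1cc(Nc2ccn(Cc3csc4ccc(Cl)cc34)n2)n2nc(SCc3ccc(Br)cc3)nc2n1` differs from compound 1 by 5-chloro-1-benzothiophen-3-yl in place of 4-methylquinazolin-2-yl on a saturated chain carbon bound to an aromatic nitrogen. For the measured compounds named here, no step between measured compounds is known, so the size of this change cannot be read from the data. The step from compound 1 to compound 3 is expected to be small, a 1.1-fold higher number from compound 1 to compound 3 (0.04 log units; within the scatter), not beyond the scatter in either direction. Compound 3 is estimated at 6000 nM, between 2000 nM and 18000 nM.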

Compound 3, half-maximal inhibitory concentration: 4350 nM
The estimate for compound 3 lay 1.4-fold (0.14 log units) above the measured number; low and high end bracket the measured number.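

In this assay, the exchange on the saturated chain carbon bound to an aromatic nitrogen gives a 1.3-fold lower number from compound 1 to compound 3 (0.10 log units; within the scatter). This first readable step at this position shows that a fused pair of rings with sulfur and chlorine can replace one with two nitrogens, and one fewer hydrogen-bond acceptor, without a change beyond the scatter. Nothing at hand bears on the cause of this step.

Open, from the compounds shown here alone, is whether a single-ring group such as phenyl, or a morpholine or carboxylic acid on this chain carbon, would give a similar number.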